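This account rests on a few compounds, and the source may have more. Where it says the series, first, only, none or still open, it means among the compounds named here.

Measured compounds in a functional assay on HEK293 cells for antagonist activity at transient receptor potential cation channel subfamily V member 1 (Homo sapiens), read by calcium flux; on this read-out higher numbers stand for weaker inhibition and lower numbers for stronger inhibition:
compound 1 `FC(F)(F)c1ccc(Nc2cccc3sc(Nc4c(Cl)cccc4Cl)nc23)cc1`; compound 2 `FC(F)(F)c1cccc(Nc2ncnc3sc(Nc4c(Cl)cccc4Cl)nc23)c1`; compound 3 `Clc1cccc(Cl)c1Nc1nc2c(Nc3ccccc3)ncnc2s1`.

In this assay compound 1 reaches only the assay limit, > 5000 nM, and gives no number. In this assay compound 2 gives 206 nM, and compound 3 gives 176 nM. Compound 3 holds the lowest of the two numbers, with compound 2 within the scatter of it. Within the data shown here, the only single-place step measured, a 1.2-fold lower number from compound 2 to compound 3 (0.07 log units; within the scatter), concerns the same aryl ring and is within the scatter.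

Compound 4 `NS(=O)(=O)c1ccc(Nc2ncnc3sc(Nc4c(Cl)cccc4Cl)nc23)cc1` differs from compound 3 by sulfamoyl in place of hydrogen on an aromatic carbon. Among the measured compounds shown here, no measured step introduces a group of this kind, so no direction is indicated. For compound 4 a step of a 1.4-fold higher number from compound 3 to compound 4 (0.15 log units; within the scatter) in this assay is expected, not clearly beyond the scatter. Compound 4 is estimated at 250 nM, range 60 nM to 1000 nM.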

Compound 4, half-maximal inhibitory concentration: > 5000 nM
Compound 4: only a limit was reported; the forecaster's own chance of this, stated with the estimate: 10%; middle value at least 20-fold (1.30 log units) away from the limit.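

In this assay, sulfamoyl in place of hydrogen on an aromatic carbon, para to a large group, shows that this ring does not tolerate every change: an at least 28-fold higher number from compound 3 to compound 4 (1.45 log units; beyond the scatter). Among these compounds, the only earlier step on this ring, a 1.2-fold lower number from compound 2 to compound 3 (0.07 log units; within the scatter), gave no such sign. Compound 4 gives > 5000 nM, which is a limit of the assay and not a number, so the step gives only a minimum size: the limit of > 5000 nM in this assay, at which 2 of the 4 values shown sit.

As far as these compounds go, whether the loss belongs to sulfamoyl itself or to any group at this place stays open. Methyl, an amine or a carboxylic acid on the same carbon would separate the two.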